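Longer linkers on the shared core: working notes

This account rests on a few compounds, and the source may have more. Where it says the series, first, only, none or still open, it means among the compounds named here.

Measured so far:
compound 1 `O=C(CI)NCCCCNc1ncnc2c1ncn2[C@@H]1O[C@H](COP(=O)(O)OP(=O)(O)OP(=O)(O)O)[C@@H](O)[C@H]1O` — 0%
compound 2 `O=C(CI)NCCCCCC(=O)NCCCCNc1ncnc2c1ncn2[C@@H]1O[C@H](COP(=O)(O)OP(=O)(O)OP(=O)(O)O)[C@@H](O)[C@H]1O` — 0%
compound 3 `CN(CCCCN(C)C(=O)CCCNc1ncnc2c1ncn2[C@@H]1O[C@H](COP(=O)(O)OP(=O)(O)OP(=O)(O)O)[C@@H](O)[C@H]1O)C(=O)CCCNC(=O)CI` — 0%

In an assay on isolated protein for inhibition of hexokinase-1 (Rattus norvegicus), with a stated time of 6 h, tested at 10 mM (a higher number here means more inhibition at the concentration tested (going by the name of the read-out), a lower number less inhibition), compound 1 gives 0% and stands level with compounds 2 and 3, its nearest neighbour being compound 2 and its furthest compound 3, both within the scatter. Going by the values given here, the one measured step that lengthens the same chain, no change at the digits printed from compound 1 to compound 2 (within the scatter), bears directly on the next change. Compound 4 `O=C(CI)NCCCCCCCNc1ncnc2c1ncn2[C@@H]1O[C@H](COP(=O)(O)OP(=O)(O)OP(=O)(O)O)[C@@H](O)[C@H]1O` is not yet measured; it differs from compound 1 by 3-(((iodomethyl)carbonyl)amino)propyl in place of ((iodomethyl)carbonyl)amino on a saturated chain carbon, four bonds along the chain from a nitrogen on an aromatic ring. Since lengthening this chain gave no step beyond the scatter from compound 1 to compound 2, no step beyond the scatter is expected here either, no change at the digits printed from compound 1 to compound 4 (within the scatter). Compound 4 is therefore estimated at 0%, with a range from 0% to 10%.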

Compound 4, a percentage reported as inhibition, at one concentration (the size of the read-out at that concentration, not a potency): 20%
Compound 4: middle estimate off by 20 percentage points, on the low side, and the stated range ends below it.
By their numbers in this assay, from the lowest: compounds 1, 2 and 3 (each within the scatter of the next); then compound 4.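

In this assay, the position on a saturated chain carbon, four bonds along the chain from a nitrogen on an aromatic ring, responds to extension: 3-(((iodomethyl)carbonyl)amino)propyl in place of ((iodomethyl)carbonyl)amino gives a number 20 percentage points higher from compound 1 to compound 4 (beyond the scatter). Added chain length alone does not account for this, as compound 2 goes against such a pattern with no change at the digits printed from compound 1 to compound 2 (within the scatter). No available evidence explains the rise.

Still open, as far as these compounds go, is whether a longer saturated chain carrying the same end group moves the read-out further. Also open, from the compounds shown here alone, is whether chloromethyl in place of iodomethyl keeps the inhibition seen with compound 4.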